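The source may hold more compounds than are shown below. What is called first, only, known or untested is meant among the compounds shown, and "the series" means these compounds.

Measured so far:
compound 1 `Nc1cc(N)c2nc(-c3ccccc3)c(Sc3ccc(F)cc3)nc2c1` — 17400 nM
compound 2 `CCOC(=O)[C@H](CCC(=O)O)NC(=O)c1ccc(Oc2nc3cc(N)cc(N)c3nc2-c2ccccc2)cc1` — 11200 nM
compound 3 `CCOC(=O)[C@H](CCC(=O)O)NC(=O)c1ccc(CNc2nc3cc(N)cc(N)c3nc2-c2ccccc2)cc1` — 26300 nM

All three were measured in a functional assay on MDA-MB-231 cells (Homo sapiens) for inhibition, read by sulforhodamine B assay, with a stated time of 48 h; a lower number here means a stronger inhibitor of growth, a higher number a weaker inhibitor of growth. Compound 1 stands second highest of the three numbers; compound 3 shows a higher number and compound 2 a lower one, but both gaps lie within the scatter, so the three are not separated. Compound 4 `Nc1cc(N)c2nc(-c3ccccc3)c(NCc3ccc(F)cc3)nc2c1` differs from compound 1 in one place: (4-fluorobenzyl)amino in place of (4-fluorophenyl)sulfanyl on an aromatic carbon. Within the data shown here, no measured pair shows this change alone, and the spread among compounds 1, 2 and 3 gives no direction beyond the scatter. The step in this assay is therefore expected to be small, if anything a slight shift to a higher number. Compound 4 is estimated at 25000 nM, range 8000 nM to 80000 nM. The expected step is a 1.4-fold higher number from compound 1 to compound 4 (0.16 log units; within the scatter).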

Compound 4, concentration for 50% growth inhibition: 2140 nM
The estimate for compound 4 lay 12-fold (1.07 log units) above the measured number; the measured number lies below the stated range.
By their numbers in this assay, from the lowest: compound 4; then compounds 2, 1 and 3 (each within the scatter of the next, the first and the last beyond it).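

In this assay, (4-fluorobenzyl)amino in place of (4-fluorophenyl)sulfanyl on the aromatic carbon next to the ring nitrogen gives an 8.1-fold lower number from compound 1 to compound 4 (0.91 log units; beyond the scatter), so this position responds to the group it carries. The entering group adds a hydrogen-bond donor and one heavy atom, and nothing shown ties the step to either difference.

The step changes the linking atom and the chain length together, leaving their shares unresolved. A (4-fluorophenyl)amino group, or a 2-(4-fluorophenyl)ethylamino chain, at this carbon would help separate them.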